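Methyl to Ethyl on a Shared Core

This account rests on a few compounds, and the source may have more. Where it says the series, first, only, none or still open, it means among the compounds named here.

Compound 1 `Cc1ccc(NC2=CC(=O)c3nc4n(c3C2=O)[C@H]2OC[C@@H](O)[C@H]2OC4)cc1` and compound 2 `COc1ccc(NC2=CC(=O)c3c(nc4n3[C@H]3OC[C@@H](O)[C@H]3OC4)C2=O)cc1` share one core and differ only in the group attached to the amino nitrogen. In a functional assay on MGC-803 cells (Homo sapiens) for inhibition, read by sulforhodamine B assay (a higher number here means a weaker inhibitor, a lower number a stronger inhibitor), compound 1 gives 1420 nM, and compound 2 gives 2150 nM; these two numbers lie within the usual scatter of each other, so compound 1 stands together with compound 2. Compound 3 `O=C1C(N2CCCCC2)=CC(=O)c2c1nc1n2[C@H]2OC[C@@H](O)[C@H]2OC1` carries piperidin-1-yl in place of (4-methoxyphenyl)amino, and in this assay compound 3 reaches only a limit, > 4000 nM (the limit of > 4000 nM in this assay, at which 1 of the 3 values shown sits). Within the data shown here, the single measured step, an at least 1.8-fold higher number from compound 2 to compound 3 (0.26 log units; that floor lies within the scatter), exchanges the whole amine and its floor lies within the scatter. Compound 4 `CCc1ccc(NC2=CC(=O)c3nc4n(c3C2=O)[C@H]2OC[C@@H](O)[C@H]2OC4)cc1` differs from compound 1 by methyl in place of hydrogen on a saturated chain carbon bound to an aromatic carbon. Among the measured compounds shown here, no measured step touches this kind of change; the one step known replaces the amine entirely and says nothing about lengthening a chain on a saturated carbon bound to an aromatic carbon. The account therefore expects compound 4 to sit with compound 1, with a 1.0-fold lower number from compound 1 to compound 4 (0.01 log units; within the scatter) within the scatter. Compound 4 is estimated at 1400 nM, between 700 nM and 2900 nM.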

Compound 4, half-maximal inhibitory concentration: 1290 nM
Estimate against measurement, compound 4: 1.1-fold (0.04 log units) above; measured number inside the range.
By their numbers in this assay, from the lowest: compounds 4, 1 and 2 (each within the scatter of the next). At a limit, above all of these: compound 3.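

In this assay, among these compounds, the new step reads a 1.1-fold lower number from compound 1 to compound 4 (0.04 log units; within the scatter), and it is the first measured change made within the aryl group on the amino nitrogen rather than to the whole amine. It shows that methyl to ethyl, on a saturated chain carbon bound to an aromatic carbon, gives no difference that can be read in this assay, so the 4-ethylphenyl group stands together with the 4-methylphenyl group here. No measured property shown here bears on this result.

From the compounds shown here alone, whether a propyl chain, a tert-butyl group or a carboxylic acid at this place would behave the same stays open. Going by these compounds, compound 3 gives only a limit, > 4000 nM, and the full size of the change from (4-methoxyphenyl)amino to piperidin-1-yl also stays open.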